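Ring size of the aryl amine: from compound 3 to compound 4

The compounds below may be only part of what the source reports. "The series", "measured", "known", "first", "only" and "open" are said of these compounds alone.

Measured compounds and their numbers in an assay for inhibition of mitogen-activated protein kinase kinase kinase 14 (Homo sapiens), read by luminescence and ADP-Glo, with a stated time of 120 min, in the presence of a further agent that is not named here; a lower number here means a stronger inhibitor, a higher number a weaker inhibitor:

compound 1 `CC(O)(C#Cc1ccc(N2CCNCC2)c(Nc2ncnc3[nH]ccc23)c1)c1nccs1` gives 47.9 nM
compound 2 `CC(O)(C#Cc1ccc(N2CC3CC2CN3)c(Nc2ncnc3[nH]ccc23)c1)c1nccs1` gives 200 nM
compound 3 `CN1CCN(c2ccc(C#CC(C)(O)c3nccs3)cc2Nc2ncnc3[nH]ccc23)CC1` gives 78.3 nM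

Compound 3 holds the second highest of the three numbers in this assay. Its nearest neighbour is compound 1, the step being a 1.6-fold higher number from compound 1 to compound 3 (0.21 log units; within the scatter), so the methyl on the ring amine nitrogen does not register. Its furthest neighbour is compound 2, with a 2.6-fold lower number from compound 2 to compound 3 (0.41 log units; beyond the scatter).

Compound 4 `CN1CCCN(c2ccc(C#CC(C)(O)c3nccs3)cc2Nc2ncnc3[nH]ccc23)CC1` carries the change (4-methyl-1,4-diazepan-1-yl in place of 4-methylpiperazin-1-yl on an aromatic carbon). Going by the values given here, the only steps that touch this part of the series are those that alter the ring amine: the swap of the six-membered ring for the two five-membered rings gave a 4.2-fold higher number from compound 1 to compound 2 (0.62 log units; beyond the scatter), and the return to a six-membered ring with a methyl gave a 2.6-fold lower number from compound 2 to compound 3 (0.41 log units; beyond the scatter), while the methyl alone gave a 1.6-fold higher number from compound 1 to compound 3 (0.21 log units; within the scatter). Among the compounds with values here, no measured step enlarges the ring by one carbon with both hetero atoms kept. The larger bicyclic ring cost a modest amount, the methyl nothing, so a small step in this assay toward a higher number, or none beyond the scatter, is expected for compound 4.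

Compound 4 is estimated at 110 nM in this assay, within 45 nM to 280 nM, which means an expected step of a 1.4-fold higher number from compound 3 to compound 4 (0.15 log units; within the scatter).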

Compound 4, half-maximal inhibitory concentration: 60.1 nM
Compound 4: the middle estimate sits 1.8-fold (0.26 log units) above what was measured, within the range that was stated.
By their numbers in this assay, from the lowest: compounds 1, 4 and 3 (each within the scatter of the next); then compound 2.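

In this assay, the ring enlargement gives a 1.3-fold lower number from compound 3 to compound 4 (0.11 log units; within the scatter), so at this aromatic carbon 4-methyl-1,4-diazepan-1-yl does not separate from 4-methylpiperazin-1-yl, and the seven-membered ring does not carry the cost seen with the two five-membered rings of compound 2. Going by these compounds alone, measured against the ring without a methyl, the change gives a 1.3-fold higher number from compound 1 to compound 4 (0.10 log units; within the scatter), so ring size and methyl taken together still do not register, whereas the change from the two five-membered rings gives a 3.3-fold lower number from compound 2 to compound 4 (0.52 log units; beyond the scatter), which leaves compound 2 as the only one of these ring amines set apart by steps beyond the scatter. Nothing in hand explains either the tolerance of the seven-membered ring or the separation of compound 2.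

Still open, as far as these compounds go, is how 1,4-diazepan-1-yl without the methyl would sit against compound 1 and compound 4, which would split ring size from methylation on the seven-membered ring. From the compounds shown here alone, it is also open whether the second ring nitrogen matters at all, a question that morpholin-4-yl would address, and whether an acetyl or 2-hydroxyethyl group on that nitrogen would stay within the scatter of methyl.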